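From 3-methylbut-2-en-1-yl to butyl on compound 1

The source may hold more compounds than are shown below. What is called first, only, known or untested is meant among the compounds shown, and "the series" means these compounds.

In an ADME assay on MCF7-DOX cells (Homo sapiens) for cytotoxicity, read by MTT assay, with a stated time of 48 h (a lower number here means a stronger inhibitor, a higher number a weaker inhibitor), compound 1 `COc1cc(OC)c(C(=O)/C=C/c2cccc(N3CCNCC3)c2)c(O)c1CC=C(C)C` gives 99900 nM. Compound 2 `COc1cc(OC)c(C(=O)/C=C/c2cccc([N+](=O)[O-])c2)c(O)c1CC=C(C)C` gives 57000 nM, and these two values lie within the scatter of each other, so neither stands apart. Compound 3 `CCCCc1c(OC)cc(OC)c(C(=O)/C=C/c2cccc(N3CCNCC3)c2)c1O` has not yet been measured. It differs from compound 1 by propyl in place of 2-methylprop-1-en-1-yl on a saturated chain carbon bound to an aromatic carbon. Going by the values given here, the only measured step, a 1.8-fold lower number from compound 1 to compound 2 (0.24 log units; within the scatter), is nitro in place of piperazin-1-yl, a change at another place, and it stays within the scatter. Among the compounds with values here, no measured step touches this chain, so no step beyond the scatter is expected in this assay. The estimate amounts to a 1.2-fold lower number from compound 1 to compound 3 (0.10 log units; within the scatter), which is within the scatter. For compound 3 the expected value is 80000 nM, with an estimated range of 35000 nM to 180000 nM.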

Compound 3, half-maximal inhibitory concentration: > 100000 nM
Compound 3 ended at the assay's limit (the forecaster's own chance of this, stated with the estimate: 20%); middle value at least 1.2-fold (0.09 log units) away from the limit.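

In this assay this result is the only one shown that bears on the chain itself: with butyl in place of 3-methylbut-2-en-1-yl, the number does not fall, so removing the double bond from this chain brings no gain on the core of compound 1. The reading for compound 3 is a limit of the assay and not a number: the limit of > 100000 nM in this assay, at which 1 of the 3 values shown sits. The result is a number no lower from compound 1 to compound 3 (the limit leaves the size open), and the size of this step cannot be read, so the result fixes only its direction.

Still open, as far as these compounds go, is whether butyl in place of 3-methylbut-2-en-1-yl would give a readable step on compound 2, which carries nitro in place of piperazin-1-yl. Also open, from the compounds shown here alone, is whether a longer chain, or an amine or a carboxylic acid at the end of this chain, would lower the number in this assay at all.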